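A few compounds are considered here, and "the series" means these few. Any claim that something is new, unique, unknown or untested is made for them only; others in the source may bear on it.

Measured compounds in an ADME assay on Vero cells (Chlorocebus sabaeus) for cytotoxicity, read by luminescence, with a stated time of 2 days; a lower number here means that less compound is tolerated, a higher number that more compound is tolerated:
- compound 1, `CCc1nc2ccccc2n1CCCCOc1ccccc1`, gives 21 uM
- compound 2, `CCc1nc2ccccc2n1CCCCOc1cccc(C)c1`, gives 19 uM
- compound 3, `CCc1nc2ccc(C)cc2n1CCCCNc1ccccc1`, gives 21 uM

Compound 1 and compound 2 differ by methyl in place of hydrogen on an aromatic carbon. The step that this change made in this assay is a 1.1-fold lower number from compound 1 to compound 2 (0.04 log units; within the scatter), so the two values sit together within the usual scatter of this kind of measurement.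

Compound 3 rests on a different core; the difference between the two cores is not broken down here. In this assay compound 3 sits level with compound 1 at the digits given, and its value and that of compound 2 also lie within the scatter of one another; no order among the three can be read from these numbers.

Compound 4, `CCc1nc2ccc(C)cc2n1CCCCNc1ccc(C)cc1`, is not yet measured. It differs from compound 3 by methyl in place of hydrogen on an aromatic carbon. For the measured compounds named here, this is the same kind of change as the one from compound 1 to compound 2, though not the same: in the first pair the methyl sits meta to a large group, in the second pair para to a large group. Going by the values given here, the only measured precedent is the step from compound 1 to compound 2, which stayed within the scatter.

On that single precedent, the step from compound 3 to compound 4 in this assay is expected to be a 1.1-fold lower number from compound 3 to compound 4 (0.02 log units; within the scatter), resting on a 1.1-fold lower number from compound 1 to compound 2 (0.04 log units; within the scatter) and on the value of compound 3, 21 uM. Compound 4 is therefore estimated at 20 uM in this assay, with a likely range from 11 uM to 38 uM.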

Compound 4, half-maximal toxic concentration: 20 uM
For compound 4 middle estimate and measured number coincide at the digits printed; the range from low to high includes it.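

In this assay, placing a methyl on the terminal aromatic ring of compound 3 gives a 1.1-fold lower number from compound 3 to compound 4 (0.02 log units; within the scatter), so this change leaves no readable mark on this core. Set beside the earlier pair, the two steps agree: the same change on two cores in this assay, a 1.1-fold lower number (0.04 log units; within the scatter) from compound 1 to compound 2 and a 1.1-fold lower number (0.02 log units; within the scatter) from compound 3 to compound 4, 1.1-fold (0.02 log units) apart, within the scatter of two such steps. This shows that the methyl change stayed within the scatter on both cores, but it rests on two pairs only, and neither step is large enough to show that a step of a fixed size carries from one core to the other; moreover, the methyl in compound 4 sits para to a large group and the methyl in compound 2 sits elsewhere on the ring, so core and position are not separated.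

Methyl is the only group that enters in these pairs, so it remains open whether a group such as an amine or a carboxylic acid on the same ring would give a step beyond the scatter, and whether such a step would then carry between the two cores. From the compounds shown here alone, a longer chain in place of the linking chain also remains open, as does the behaviour of the methyl change in any assay other than this one.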